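Pyridine-carboxamide anilides on HL-60: a small, weak series

This account rests on a few compounds, and the source may have more. Where it says the series, first, only, none or still open, it means among the compounds named here.

Compound 1 `O=C(Nc1cc(C(F)(F)F)ccc1NC1CCCCC1)c1ccncc1` and compound 2 `O=C(Nc1cc(C(F)(F)F)ccc1NC1CCCCC1)c1cccnc1` share one core and differ only in the pyridine attachment. In a functional assay on HL-60 cells (Homo sapiens) for cytotoxicity, read by MTT assay, with a stated time of 48 h (a higher number here means a weaker inhibitor, a lower number a stronger inhibitor), compound 1 gives 59200 nM, and in this assay compound 2 gives 48300 nM. The step of a 1.2-fold lower number from compound 1 to compound 2 (0.09 log units; within the scatter) comes from the change (pyridin-3-yl in place of pyridin-4-yl on a carbonyl carbon). The same change, at the same place, separates compound 3 `O=C(Nc1cc(C(F)(F)F)ccc1N1CCCC1)c1ccncc1` from compound 4 `O=C(Nc1cc(C(F)(F)F)ccc1N1CCCC1)c1cccnc1`, namely (pyridin-3-yl in place of pyridin-4-yl on a carbonyl carbon). The two cores differ by pyrrolidin-1-yl in place of cyclohexylamino on an aromatic carbon. In this assay, within the data shown here, compound 3 gives "not active" (no number reported), with no single number, so no step from compound 3 to compound 4 can be computed.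

Given that the change between compound 1 and compound 2 left the number essentially unmoved, the expected step from compound 3 to compound 4 in this assay is of similarly small size, which would leave compound 4 in the same inactive range as compound 3. For compound 4 the expected value in this assay is 150000 nM, within 60000 nM to 400000 nM, with a high chance that only a limit is reported.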

Compound 4, half-maximal inhibitory concentration: "not active" (no number reported)
No number was reported for compound 4; there is nothing to compare the estimate with.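

In this assay, among these compounds, compound 3 gives "not active" (no number reported) and compound 4 gives "not active" (no number reported), so no step between them can be read. The compounds shown leave open whether pyridin-3-yl in place of pyridin-4-yl moves the number at all on the core of compound 3. No supporting evidence bears on this result.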